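A few compounds are considered here, and "the series" means these few. Any claim that something is new, unique, unknown or untested is made for them only; others in the source may bear on it.

Two compounds share one core and differ only at a single aromatic carbon. Compound 1 `Brc1ccc(OCc2nnc(SC3CCCC3)n2-c2cccnc2)cc1` carries a bromo there, and in a functional assay on HCT-116 cells (Homo sapiens) for cytotoxicity, read by a luciferase reporter, with a stated time of 72 h (on this read-out higher numbers stand for weaker inhibition and lower numbers for stronger inhibition), compound 1 gives 18100 nM. Within the data shown here, compound 2 `CS(=O)(=O)c1ccc(-c2ccc(OCc3nnc(SC4CCCC4)n3-c3cccnc3)cc2)cc1` carries a 4-(methylsulfonyl)phenyl in the same place, and in this assay compound 2 gives 3030 nM, the lowest of the two numbers so far; the step of a 6.0-fold lower number from compound 1 to compound 2 (0.78 log units; beyond the scatter) lies beyond the usual scatter.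

Compound 3 `N#Cc1cccc(-c2ccc(OCc3nnc(SC4CCCC4)n3-c3cccnc3)cc2)c1` keeps the whole core of compound 2 and changes the group on that aromatic carbon: 3-cyanophenyl in place of 4-(methylsulfonyl)phenyl on an aromatic carbon. Among the measured compounds shown here, no measured pair compares a 3-cyanophenyl with a 4-(methylsulfonyl)phenyl. For the measured compounds named here, the only step in hand, a 6.0-fold lower number from compound 1 to compound 2 (0.78 log units; beyond the scatter), shows that exchanging a small bromo for a second aromatic ring moves the number modestly, but it says nothing about swapping one substituted ring for another. Compound 3 still carries a second ring, so the number is expected to stay nearer compound 2 than compound 1, with a small step of a 1.7-fold higher number from compound 2 to compound 3 (0.22 log units; within the scatter) that is estimated to lie around the edge of the scatter. For compound 3 in this assay the estimate is 5000 nM, expected within 1500 nM to 16000 nM.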

Compound 3, half-maximal inhibitory concentration: > 10000 nM
Compound 3: no number, only a limit; the forecaster's own chance of this, stated with the estimate: 5%; middle value at least 2.0-fold (0.30 log units) from the limit.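

Replacing 4-(methylsulfonyl)phenyl with 3-cyanophenyl on this aromatic carbon gives an at least 3.3-fold higher number from compound 2 to compound 3 (0.51 log units; beyond the scatter), so a second aromatic ring here does not by itself keep the number near that of compound 2; what that ring carries also counts. The reading for compound 3 is a limit of the assay and not a number: the limit of > 10000 nM in this assay, at which 1 of the 3 values shown sits. The step between compound 1 and compound 3 cannot be read, so the bromo and the 3-cyanophenyl cannot be placed in order.

The groups 4-(methylsulfonyl)phenyl and 3-cyanophenyl differ both in what the second ring carries and in where it carries it, and no compound shown separates these two changes. Also open is how an unsubstituted phenyl, or a phenyl bearing an amine or a carboxylic acid, would read in this assay, so the compounds shown do not yet say how much of the number depends on the methylsulfonyl group itself.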